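From a Pentyl Amide to a Methylsulfonyl Ester

This account rests on a few compounds, and the source may have more. Where it says the series, first, only, none or still open, it means among the compounds named here.

Compound 1 `CCCCCC(=O)Nc1ccc2[nH]cc(C3CCN(C)CC3)c2n1` gives 13 nM in an assay for binding affinity to 5-hydroxytryptamine receptor 1F (Homo sapiens), read by radioligand binding; a lower number here means a stronger inhibitor, a higher number a weaker inhibitor.
Compound 2 `CCCCCCCC(=O)Nc1ccc2[nH]cc(C3CCN(C)CC3)c2n1` gives 20 nM in this assay.
Compound 3 `Cc1cccc(C(=O)Nc2ccc3[nH]cc(C4CCN(C)CC4)c3n2)c1` gives 5.8 nM in this assay.

Among these three numbers compound 1 stands second highest. Its nearest neighbour is reached by a 1.5-fold higher number from compound 1 to compound 2 (0.19 log units; within the scatter), its furthest by a 2.2-fold lower number from compound 1 to compound 3 (0.35 log units; beyond the scatter). The third step, a 3.4-fold lower number from compound 2 to compound 3 (0.54 log units; beyond the scatter), points the same way as the second.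

Compound 4 `CN1CCC(c2c[nH]c3ccc(OS(C)(=O)=O)nc23)CC1` is the next compound to be measured. It differs from compound 1 in a single place: (methylsulfonyl)oxy in place of (pentylcarbonyl)amino on an aromatic carbon. All three measured steps keep the amide and change only what sits on its carbonyl carbon, so none of them speaks directly to the loss of the amide itself. They do show that changes at this end of the molecule have so far moved the number only modestly, and that the hydrogen-bond donor of the amide was present in every compound that gave a low number. For compound 4 a shift beyond the scatter toward a higher number is therefore expected, but without a close precedent the size is uncertain. Compound 4 is estimated at 50 nM, with a range from 10 nM to 300 nM, which means an expected 3.8-fold higher number from compound 1 to compound 4 (0.59 log units; beyond the scatter).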

Compound 4, inhibition constant: 4.7 nM
For compound 4 the middle estimate is 11-fold (1.03 log units) above the measured one, and the stated range ends above it.
By their numbers in this assay, from the lowest: compounds 4 and 3 (each within the scatter of the next); then compounds 1 and 2 (each within the scatter of the next).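

In this assay, putting (methylsulfonyl)oxy on this aromatic carbon, next to the ring nitrogen, gives a 2.8-fold lower number from compound 1 to compound 4 (0.44 log units; beyond the scatter), so the whole (pentylcarbonyl)amino group can leave this position and the number still improves. The earlier steps shown here changed only what sits on the carbonyl carbon and kept the amide in place, whereas this step removes the amide itself, and with it the amide hydrogen. A low number at this position therefore does not require a hydrogen-bond donor in this group, and the long pentyl chain is not required either, although no measurement shown here explains why the number falls.

This single step changes several things together: the linking atom, the carbonyl replaced by a sulfonyl, and the chain replaced by a methyl, so the compounds shown cannot say which of these changes matters. A (methylsulfonyl)amino group, which keeps the sulfonyl but links through nitrogen, and a (pentylcarbonyl)oxy ester, which keeps the chain and carbonyl but links through oxygen, would begin to pull these changes apart.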